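Removing one acetyl from the diacetylamino compound

The compounds below may be only part of what the source reports. "The series", "measured", "known", "first", "only" and "open" are said of these compounds alone.

Among the compounds with values here, in an ADME assay on J774 cells (Mus musculus) for cytotoxicity, read by MTT assay, with a stated time of 48 h (a lower number here means a stronger inhibitor, a higher number a weaker inhibitor), compound 1 (`CCOCC(=O)NCCNc1cc(/C=C/c2ccccc2)nc2ccccc12`) gives 22200 nM, the only true number so far. Compound 2 (`CC(=O)N(C(C)=O)c1cc(/C=C/c2ccccc2)nc2ccccc12`) reads > 25000 nM, which is a limit of the assay and not a number. Its position is therefore known only as that limit.

Compound 3 (`CC(=O)Nc1cc(/C=C/c2ccccc2)nc2ccccc12`) has hydrogen in place of acetyl on an amide-type nitrogen, diacetylamino to acetamido: hydrogen in place of acetyl on an amide-type nitrogen. Within the data shown here, no measured pair shows this change, so the expectation has little to rest on. The nearest number is that of compound 1 at 22200 nM. A modest step of an at least 1.3-fold lower number from compound 2 to compound 3 (0.11 log units; that floor lies within the scatter) is expected in this assay, towards a lower number and possibly none beyond the scatter. A limit may well be reported again. For compound 3 the estimated value is 19000 nM, with an expected range of 8000 nM to 40000 nM.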

Compound 3, half-maximal inhibitory concentration: > 25000 nM
Compound 3: a limit, no number; the forecaster's own chance of this, stated with the estimate: 40%; middle value at least 1.3-fold (0.11 log units) from the limit.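

In this assay, compound 3 also reads as a limit and not a number, so losing one acetyl from the amide-type nitrogen brings no readable gain in cytotoxicity at this position. Neither the step for hydrogen in place of acetyl nor any other step between the two limits can be read, because both ends sit at the same limit: the limit of > 25000 nM in this assay, at which 2 of the 3 values shown sit.

Against the one true number, acetyl in place of 2-(((ethoxymethyl)carbonyl)amino)ethyl on a nitrogen on an aromatic ring gives an at least 1.1-fold higher number from compound 1 to compound 3 (0.05 log units; that floor lies within the scatter), so this floor does not separate the two compounds.

On these data alone, the true values of compound 2 and compound 3 remain open. Also open, as far as these compounds go, is whether a free amine or a longer acyl chain on this nitrogen would give a number in this assay.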